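A few compounds are considered here, and "the series" means these few. Any claim that something is new, unique, unknown or untested is made for them only; others in the source may bear on it.

Measured in a functional assay on RCC4 cells (Homo sapiens) for inhibition, read by XTT assay, with a stated time of 4 days; on this read-out lower numbers stand for stronger inhibition and higher numbers for weaker inhibition:
Compound 1 `Clc1ccccc1Nc1nc(-c2ccncc2)cs1` gives 28200 nM.
Compound 2 `CCc1cnccc1-c1csc(Nc2cccc(C)c2)n1` gives 6310 nM.
Compound 3 `Fc1ccccc1Nc1nc(-c2ccncc2)cs1` gives 14500 nM.

Among these three numbers compound 3 holds the second highest place. Its nearest neighbour is compound 1, and the change from compound 1 to compound 3, fluoro in place of chloro on an aromatic carbon, gave a 1.9-fold lower number from compound 1 to compound 3 (0.29 log units; within the scatter), a step that stays within the scatter. Going by the values given here, compound 2 lies furthest from compound 3; its number is lower, and that gap is beyond the scatter, but compound 2 differs from compound 3 in more than one place, so no single step is drawn between them.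

Compound 4 `FC(F)(F)c1ccccc1Nc1nc(-c2ccncc2)cs1` is not yet measured. It differs from compound 3 by trifluoromethyl in place of fluoro on an aromatic carbon. Among the compounds with values here, the only measured step that bears on this place is the one from compound 1 to compound 3, a swap of one halogen for another that stayed within the scatter. Within the data shown here, no measured pair shows a trifluoromethyl. On that basis compound 4 is expected to move from compound 3 by a 1.4-fold higher number from compound 3 to compound 4 (0.14 log units; within the scatter), a step not beyond the scatter. The estimate for compound 4 in this assay is 20000 nM, with a range from 7000 nM to 60000 nM.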

Compound 4, half-maximal inhibitory concentration: 40700 nM
The estimate for compound 4 lay 2.0-fold (0.31 log units) below the measured number; measured number inside the range.
By their numbers in this assay, from the lowest: compound 2; then compounds 3, 1 and 4 (each within the scatter of the next, the first and the last beyond it).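

In this assay this place, on an aromatic carbon of a six-membered aromatic ring of carbon only, now gives a step beyond the scatter: trifluoromethyl in place of fluoro yields a 2.8-fold higher number from compound 3 to compound 4 (0.45 log units; beyond the scatter), a modest change, where the earlier swap of one halogen for another had stayed within it. Trifluoromethyl in place of chloro yields a 1.4-fold higher number from compound 1 to compound 4 (0.16 log units; within the scatter), which stays within the scatter, so chloro cannot be told apart from either of the other two groups, and only fluoro and trifluoromethyl are separated. The place is thus not indifferent to what sits on it, yet the effect seen is small, and neither of the other two groups gives a number beyond the scatter below that of compound 3. Nothing at hand explains why the number moves with this change.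

The compounds shown leave open how an amine, a hydroxyl or a carboxylic acid would read at this place, and how plain hydrogen there would compare with the halogens. Also open, as far as these compounds go, is whether trifluoromethyl would give a like step on the core of compound 2.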